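The source may report more compounds than this note shows. Statements on the series, on what has been measured and on what is new or still open speak of the compounds shown alone.

Measured so far in a functional assay on the whole organism for inhibition, with Lemna aequinoctialis as the target, tested at 10 ug/mL; a higher number here means more inhibition of growth at the concentration tested, a lower number less inhibition of growth:
- compound 1 `C=CCNC(=S)N/N=C1\C(=O)Nc2ccc([N+](=O)[O-])cc21`: 25%
- compound 2 `Cc1ccc(NC(=S)N/N=C2\C(=O)Nc3ccc([N+](=O)[O-])cc32)cc1`: 15%
- compound 3 `O=C1Nc2ccc([N+](=O)[O-])cc2/C1=N/NC(=S)Nc1ccc(Br)cc1`: 10%

In this assay, compound 3 stands level with compound 2 within the scatter, as shown by a number 5 percentage points lower from compound 2 to compound 3 (within the scatter). It sits clearly apart from compound 1, with a number 15 percentage points lower from compound 1 to compound 3 (beyond the scatter).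

The next compound is compound 4 `N#Cc1cccc(NC(=S)N/N=C2\C(=O)Nc3ccc([N+](=O)[O-])cc32)c1`, which has 3-cyanophenyl in place of 4-bromophenyl on an amide-type nitrogen.

Going by the values given here, the closest precedent is the exchange of bromo for methyl on the aromatic ring, which gave a number 5 percentage points lower from compound 2 to compound 3 (within the scatter). The two steps that replace allyl on the same nitrogen are less direct, since compound 4 keeps a phenyl ring there. They gave a number 10 percentage points lower from compound 1 to compound 2 (within the scatter) and a number 15 percentage points lower from compound 1 to compound 3 (beyond the scatter), and so show only a modest spread for a change at this nitrogen. Among the compounds with values here, no measured compound carries a nitrile, so the data offer no direct read on that group, and the range is kept wide on the upper side.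

No step beyond the scatter is expected in this assay. The estimated step is a number 5 percentage points higher from compound 3 to compound 4 (within the scatter).

For compound 4 the expected value is 15%, with an estimated range of 5% to 30%.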

Compound 4, percent growth inhibition at one concentration: 5%
For compound 4 the middle estimate is 10 percentage points above the measured one, and the stated range covers the measured number.
By their numbers in this assay, from the lowest: compounds 4, 3, 2 and 1 (each within the scatter of the next, the first and the last beyond it).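

In this assay the 3-cyanophenyl group on the amide-type nitrogen brings in a nitrile, yet it stays level with the other two phenyl groups, with a number 5 percentage points lower from compound 3 to compound 4 (within the scatter) and a number 10 percentage points lower from compound 2 to compound 4 (within the scatter). Against allyl the same group gives a number 20 percentage points lower from compound 1 to compound 4 (beyond the scatter), which makes compound 4 the second phenyl compound to separate from compound 1 after compound 3, while compound 2 remains within the scatter of compound 1 and so goes against a clean split between allyl and phenyl groups at this nitrogen. No available evidence bears on why these numbers fall as they do.

On these data alone, all four compounds rest on a single read-out at one concentration, so it remains open whether any group at this nitrogen can lift growth inhibition clearly above the level of compound 1, for example a longer alkyl chain, a benzyl group, or a phenyl ring carrying a carboxylic acid or an amine. As far as these compounds go, it is also open how much the shared core contributes, for example if an amine replaced its nitro group.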